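Shortening the chain on compound 1: hexyl to isopentyl

The compounds below may be only part of what the source reports. "The series", "measured", "known", "first", "only" and "open" are said of these compounds alone.

Of the compounds shown here, three sharing one core have been measured in a functional assay on EOL1 cells (Homo sapiens) for inhibition, read by fluorescence, with a stated time of 72 h; on this read-out higher numbers stand for weaker inhibition of growth and lower numbers for stronger inhibition of growth. Compound 1 `CCCCCCn1cnc2c(Nc3ccc(O)cc3)nc(N[C@H]3CC[C@H](N)CC3)nc21` gives 190 nM. Compound 2 `CCCCn1cnc2c(Nc3cccc(Cl)c3)nc(N[C@H]3CC[C@H](N)CC3)nc21`, which carries a chlorophenyl group and a shorter chain, gives 160 nM, and compound 3 `CCCCn1cnc2c(Nc3cc(OC)cc(OC)c3)nc(N[C@H]3CC[C@H](N)CC3)nc21`, with a dimethoxyphenyl group, gives 370 nM. Among the measured compounds shown here, the only one-place step among them, a 2.3-fold higher number from compound 2 to compound 3 (0.36 log units; beyond the scatter), concerns the aromatic group rather than the chain. For the measured compounds named here, compound 1 sits within the usual scatter of both compound 2 and compound 3, so nothing distinguishes the three beyond the single step just named.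

Compound 4 `CC(C)CCn1cnc2c(Nc3ccc(O)cc3)nc(N[C@H]3CC[C@H](N)CC3)nc21` keeps everything of compound 1 except its chain: isopropyl in place of butyl on a saturated chain carbon, two bonds along the chain from an aromatic nitrogen. Going by the values given here, no measured step touches this part of the molecule, so the change from compound 1 to compound 4 has no direct precedent here. Among the compounds with values here, the one step that is known, between compound 2 and compound 3, changes a different group and gives no guidance on a branched, shorter chain.

With nothing in the data pointing one way or the other, the step of a 1.2-fold higher number from compound 1 to compound 4 (0.06 log units; within the scatter) is expected to stay within the scatter. Compound 4 is therefore estimated at 220 nM, with a range from 90 nM to 550 nM.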

Compound 4, concentration for 50% growth inhibition: 30 nM
The estimate for compound 4 lay 7.3-fold (0.87 log units) above the measured number; the measured number lies below the stated range.
By their numbers in this assay, from the lowest: compound 4; then compounds 2, 1 and 3 (each within the scatter of the next, the first and the last beyond it).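

The chain is not a silent part of the molecule: in this assay, the hexyl to isopentyl change, read at its outer cut as isopropyl in place of butyl on a saturated chain carbon, gives a 6.3-fold lower number from compound 1 to compound 4 (0.80 log units; beyond the scatter), which means stronger inhibition of growth. Among the compounds shown here, until now, the only one-place step concerned the aromatic group, so this is the first direct sign that growth inhibition also responds to the chain on the aromatic nitrogen. Nothing available here explains why this change has such an effect.

The step shortens the chain and adds a branch at once, so the compounds shown cannot separate the two; a straight pentyl chain or a cyclopentyl ring on the same nitrogen would help to tell them apart. On these data alone, it also remains open whether the isopentyl chain would have a similar effect alongside the chlorophenyl group of compound 2 or the dimethoxyphenyl group of compound 3, as this step was read only with the hydroxyphenyl group of compound 1.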